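A few compounds are considered here, and "the series" means these few. Any claim that something is new, unique, unknown or untested is made for them only; others in the source may bear on it.

Working notes on the series. Compound 1 `COc1ccccc1-n1c(SCC(=O)Nc2nc3ccc(C)cc3s2)nc2c(c1=O)SCC2`, compound 2 `O=C(CSc1nc2c(c(=O)n1-c1ccccc1)SCC2)Nc1ccc(-c2ccncc2)cc1` and compound 3 `O=C(CSc1nc2c(c(=O)n1-c1ccccc1)SCC2)Nc1ncc(-c2ccco2)cn1` share one core and differ only in the aryl group bound to the amide. In an assay on L cells for inhibition of Protein-serine O-palmitoleoyltransferase porcupine (Mus musculus), read by reporter gene assay, with a stated time of 24 h (on this read-out higher numbers stand for an effect only at larger amounts of compound and lower numbers for an effect already at smaller amounts), compound 1 gives 25 nM, compound 2 gives 3 nM and compound 3 gives 3.5 nM. Compound 3 and compound 2 lie within the scatter of each other, while compound 1 lies beyond the scatter from compound 3, with the higher number. Compound 4 `O=C(CSc1nc2c(c(=O)n1-c1ccccc1)SCC2)Nc1ncc(-c2ccccc2)cn1` is not yet measured and differs from compound 3 in one place: phenyl in place of furan-2-yl on an aromatic carbon. Among the measured compounds shown here, no measured step of this kind exists in the set. Compound 2, also carrying a six-membered aromatic ring on the aryl attached to its amide, gives 3 nM, so no step beyond the scatter is expected for a 1.1-fold higher number from compound 3 to compound 4 (0.06 log units; within the scatter) in this assay. Compound 4 is estimated at 4 nM, with a range from 1.5 nM to 12 nM.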

Compound 4, half-maximal effective concentration: 15 nM
Estimate against measurement, compound 4: 3.8-fold (0.57 log units) below; measured number above the stated range.
By their numbers in this assay, from the lowest: compounds 2 and 3 (each within the scatter of the next); then compounds 4 and 1 (each within the scatter of the next).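

Among the compounds shown here, the step (a 4.3-fold higher number from compound 3 to compound 4 (0.63 log units; beyond the scatter)) in this assay is the first measured single-place change, and it shows that this aromatic carbon does not tolerate every aromatic ring equally. Phenyl in place of furan-2-yl changes ring size and removes the ring hetero atom together, so the step cannot be assigned to either change alone. Nothing measured here explains the step.

From the compounds shown here alone, it remains open whether thiophen-2-yl, a five-membered ring with sulfur, or an amine on this carbon would read closer to compound 3 or compound 4.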